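The source may hold more compounds than are shown below. What is called first, only, known or untested is meant among the compounds shown, and "the series" means these compounds.

Compound 1 `CCN(CC)CCCCOc1c(OCc2ccccc2)cc2oc(-c3ccccc3)cc(=O)c2c1O` gives 2200 nM in a functional assay on HepG2 cells (Homo sapiens) for antiproliferative activity, read by MTT assay, with a stated time of 48 h; a lower number here means a stronger inhibitor, a higher number a weaker inhibitor. Compound 2 `CN1CCN(CCCOc2c(OCc3ccccc3)cc3oc(-c4ccccc4)cc(=O)c3c2O)CC1` gives 2400 nM in the same assay and has the higher of the two numbers, with a 1.1-fold higher number from compound 1 to compound 2 (0.04 log units; within the scatter) separating it from compound 1. Compound 3 `CN(C)CCCOc1c(OCc2ccccc2)cc2oc(-c3ccccc3)cc(=O)c2c1O` differs from compound 2 only at the end of the chain, where (dimethylamino in place of 4-methylpiperazin-1-yl on a saturated chain carbon, three bonds along the chain from an oxygen on an aromatic ring). Going by the values given here, the one measured step also swapped the amine at that end of the chain and stayed within the scatter, so for compound 3 no step beyond the scatter is expected, a 1.0-fold lower number from compound 2 to compound 3 (0.02 log units; within the scatter). Compound 3 is therefore estimated at 2300 nM, between 1100 nM and 4800 nM.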

Compound 3, half-maximal inhibitory concentration: 2200 nM
For compound 3 the middle estimate is 1.0-fold (0.02 log units) above the measured one; measured number inside the range.
By their numbers in this assay, from the lowest: compounds 1, 3 and 2 (each within the scatter of the next).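

In this assay, dimethylamino in place of 4-methylpiperazin-1-yl gives a 1.1-fold lower number from compound 2 to compound 3 (0.04 log units; within the scatter), and dimethylamino in place of (diethylamino)methyl gives no change at the digits printed from compound 1 to compound 3 (within the scatter). At this place on the chain, then, the open dimethylamino group and the ring-bearing 4-methylpiperazin-1-yl group cannot be told apart in this assay, and the same holds for the compound 1 side chain. Nothing measured here speaks to why these amines read alike.

Still open, on these data alone, is whether a morpholin-4-yl group or a carboxylic acid at the chain end would read the same. As far as these compounds go, a longer chain carrying dimethylamino is equally open.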